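A few compounds are considered here, and "the series" means these few. Any claim that something is new, unique, unknown or untested is made for them only; others in the source may bear on it.

Compound 1 `Cc1ccccc1NS(=O)(=O)c1ccc(NC(=O)NCCCCl)cc1` and compound 2 `CCc1ccccc1NS(=O)(=O)c1ccc(NC(=O)NCCCCl)cc1` share one core, and compound 3 `CCNC(=O)Nc1cccc(S(=O)(=O)Nc2ccccc2CC)c1` with compound 4 `CCCc1ccccc1NS(=O)(=O)c1cccc(NC(=O)NCC)c1` share another; the difference between the two cores is not broken down here. All were examined, or are to be examined, in a functional assay on MCF7 cells (Homo sapiens) for cytotoxicity, read by sulforhodamine B assay, with a stated time of 48 h; on this read-out higher numbers stand for weaker inhibition and lower numbers for stronger inhibition.

Compound 1 gives a value in this assay that is a limit of the assay, > 200000 nM. Compound 2 likewise gives only a limit in this assay, > 200000 nM. The change from compound 1 to compound 2 is methyl in place of hydrogen on a saturated chain carbon bound to an aromatic carbon, and the step that the two limits leave unreadable from compound 1 to compound 2 cannot be read because both values sit at the limit of > 200000 nM in this assay, at which 2 of the 3 values shown sit.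

Compound 3 is the only one of the three with a number in this assay, giving 48000 nM. The change to compound 4 is methyl in place of hydrogen on a saturated chain carbon, two bonds along the chain from an aromatic carbon. It is the same kind of change as that from compound 1 to compound 2, though not the same: in the earlier pair the new methyl sits on a saturated chain carbon bound to an aromatic carbon, while here it sits on a saturated chain carbon two bonds along the chain from an aromatic carbon.

Since the earlier step is unreadable, it offers no size to lean on. The expectation is therefore that the step from compound 3 to compound 4 stays within the usual scatter, a 1.1-fold lower number from compound 3 to compound 4 (0.03 log units; within the scatter). Compound 4 is thus estimated at 45000 nM, with a likely range from 15000 nM to 130000 nM.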

Compound 4, half-maximal inhibitory concentration: 40000 nM
Compound 4: middle estimate off by 1.1-fold (0.05 log units), on the high side, within the range that was stated.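

In this assay the new step is a 1.2-fold lower number from compound 3 to compound 4 (0.08 log units; within the scatter), so methyl in place of hydrogen at this place on the chain has no effect that can be told from the usual scatter on the core of compound 3. The same kind of change on the other core, from compound 1 to compound 2, cannot be read, because both compounds give only a limit of the assay and not a number: the limit of > 200000 nM in this assay, at which 2 of the 4 values shown sit. The series therefore shows one readable step on one core, at a different place on the chain from the earlier change, and it does not show whether the change carries from one core to the other, either in size or in direction.

Going by these compounds, it remains open whether a butyl chain, or an amine or a carboxylic acid, in place of the propyl chain of compound 4 would give a step beyond the scatter on this core. On these data alone, it also remains open how the core of compound 1 would respond to such a change if a compound on that core gave a number rather than a limit.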